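This account rests on a few compounds, and the source may have more. Where it says the series, first, only, none or still open, it means among the compounds named here.

Series notes. Compound 1 `CC/C(=C(/c1ccc(/C=C/C(=O)O)cc1)c1cc2ccccc2[nH]1)c1ccccc1` carries phenyl on the double-bonded chain carbon bound to a double-bonded chain carbon and a saturated chain carbon; in a functional assay on MCF7 cells (Homo sapiens) for inhibition (on this read-out higher numbers stand for weaker inhibition and lower numbers for stronger inhibition), compound 1 gives 108 nM. Compound 2 `CC/C(=C(/c1ccc(/C=C/C(=O)O)cc1)c1cc2ccccc2[nH]1)c1ccc(C#N)cc1Cl` gives 49 nM and compound 3 `CC/C(=C(/c1ccc(/C=C/C(=O)O)cc1)c1cc2ccccc2[nH]1)c1ccc(Cl)cc1C#N` gives 14 nM. Compound 3 stands lowest of the three numbers: the step of a 7.7-fold lower number from compound 1 to compound 3 (0.89 log units; beyond the scatter) is the largest, a 3.5-fold lower number from compound 2 to compound 3 (0.54 log units; beyond the scatter) is smaller, and a 2.2-fold lower number from compound 1 to compound 2 (0.34 log units; beyond the scatter) is the smallest, all beyond the scatter.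

Compound 4 `CC/C(=C(/c1ccc(/C=C/C(=O)O)cc1)c1cc2ccccc2[nH]1)c1cc(Cl)ccc1Cl` has not yet been measured. It differs from compound 3 by 2,5-dichlorophenyl in place of 4-chloro-2-cyanophenyl on a double-bonded chain carbon bound to a double-bonded chain carbon and a saturated chain carbon. All three measured steps alter the same phenyl and bear on this change, but none puts in 2,5-dichlorophenyl, and none removes the nitrile while keeping chlorine, so the direction rests on the pattern that both substituted rings gave lower numbers than phenyl. Losing the nitrile of compound 3 is expected to give back part of the step of a 7.7-fold lower number from compound 1 to compound 3 (0.89 log units; beyond the scatter), with the remaining chlorines holding the number below that of compound 1.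

Compound 4 is therefore expected near 40 nM in this assay, with a range of 12 nM to 130 nM. The expected step is a 2.9-fold higher number from compound 3 to compound 4 (0.46 log units; beyond the scatter), a rise beyond the scatter.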

Compound 4, half-maximal inhibitory concentration: 71 nM
Compound 4: middle estimate off by 1.8-fold (0.25 log units), on the low side; measured number inside the range.
By their numbers in this assay, from the lowest: compound 3; then compounds 2, 4 and 1 (each within the scatter of the next, the first and the last beyond it).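

Working from the pattern so far, a 5.1-fold higher number from compound 3 to compound 4 (0.71 log units; beyond the scatter) shows in this assay that the low number of compound 3 does not carry over to every chlorinated ring at this double-bonded chain carbon: 2,5-dichlorophenyl does not match 4-chloro-2-cyanophenyl here. The earlier pattern, in which both substituted rings gave lower numbers than phenyl, does not hold beyond the scatter for compound 4, since a 1.5-fold lower number from compound 1 to compound 4 (0.18 log units; within the scatter) and a 1.4-fold higher number from compound 2 to compound 4 (0.16 log units; within the scatter), even though a 2.2-fold lower number from compound 1 to compound 2 (0.34 log units; beyond the scatter). Nothing available explains these differences at this position.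

Open, from the compounds shown here alone, is whether a phenyl carrying the nitrile alone, without chlorine, would reach the number of compound 3, and whether a methoxy or a carboxamide in place of that nitrile would do the same. Going by these compounds, the shared core stays fixed throughout, so it is also open whether these rings would keep their order with an amide in place of the carboxylic acid.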